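This account rests on a few compounds, and the source may have more. Where it says the series, first, only, none or still open, it means among the compounds named here.

Compound 1 `Cc1cccc(Cn2c(CN3CCN(C(=O)c4ccc(C(F)(F)F)cc4)CC3)nc3ccccc32)c1` has the lower of the two measured numbers in an assay on isolated protein for inhibition of aldehyde dehydrogenase 1A1 (Homo sapiens), read by spectrophotometry, tested at 10 uM; on this read-out lower numbers stand for less inhibition and higher numbers for more inhibition at the one concentration tested (going by the name of the read-out): compound 1 gives 22.9%, while compound 2 `CC(C)CCn1c(OC2CCN(C(=O)C3CC3)CC2)nc2ccccc21` gives 56.4%, a gap beyond the usual scatter. Compound 3 `CCc1ccc(C(=O)N2CCN(Cc3nc4ccccc4n3Cc3cccc(C)c3)CC2)cc1` differs from compound 1 in one place: ethyl in place of trifluoromethyl on an aromatic carbon. Among the measured compounds shown here, no pair of measured compounds shows what such a swap does, so there is no measured guide here. The step is expected to be small, in either direction or none beyond the scatter, as the estimated change a number 2.1 percentage points higher from compound 1 to compound 3 (within the scatter). Compound 3 is therefore expected to come out near 25%, somewhere between 5% and 50%.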

Compound 3, a percentage reported as inhibition, at one concentration (the size of the read-out at that concentration, not a potency): 67%
Estimate against measurement, compound 3: 42 percentage points below; measured number above the stated range.
By their numbers in this assay, from the lowest: compound 1; then compound 2; then compound 3.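

In this assay, putting ethyl in place of trifluoromethyl on this aromatic carbon goes with a number 44.1 percentage points higher from compound 1 to compound 3 (beyond the scatter). Among the compounds shown here, with the rest of the molecule unchanged, this single position clearly matters for the read-out, which the earlier compounds, differing in many places, could not show. Nothing measured here explains the size of this step. Still open, as far as these compounds go, is whether a longer chain such as propyl, an amine or a carboxylic acid at this position would keep the higher number, and whether the same swap would act similarly on a different core.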